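The source may hold more compounds than are shown below. What is called first, only, known or untested is meant among the compounds shown, and "the series" means these compounds.

In an assay on HEK293 cells for agonist activity at transient receptor potential cation channel subfamily M member 8 (Homo sapiens), read by fluorescence and calcium flux, with a stated time of 15 min (on this read-out lower numbers stand for an effect already at smaller amounts and higher numbers for an effect only at larger amounts of compound), compound 3 `CCC(C)N(Cc1cccs1)C(=O)COc1ccc(C)cc1` gives 2000 nM, the second highest of the three numbers recorded. Compound 1 `CCN(Cc1cccs1)C(=O)COc1ccc(C#N)cc1` gives 1990 nM, a value within the scatter of that of compound 3, while compound 2 `Cc1ccc(OCC(=O)N(O)Cc2cccs2)cc1` gives 8000 nM; the step of a 4.0-fold lower number from compound 2 to compound 3 (0.60 log units; beyond the scatter) is modest but beyond the scatter. Compound 4 `CCN(Cc1cccs1)C(=O)COc1ccc(C)cc1` differs from compound 3 by hydrogen in place of ethyl on a saturated chain carbon bound to an amide-type nitrogen and a saturated chain carbon. Going by the values given here, no measured step covers this change directly; compound 1 already carries the ethyl group and sits within the scatter of compound 3, which gives no sign that the substituent at this place shifts the read-out much. Compound 4 is therefore expected to show no change at the digits printed from compound 3 to compound 4 (within the scatter), with an estimated value of 2000 nM and a range from 700 nM to 6000 nM.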

Compound 4, half-maximal effective concentration: 8 nM
Beside the measured number, compound 4's estimate is 250-fold (2.40 log units) above it; measured number outside the range, below it.
By their numbers in this assay, from the lowest: compound 4; then compounds 1 and 3 (each within the scatter of the next); then compound 2.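

On the amide-type nitrogen, the change from sec-butyl to ethyl brings a 250-fold lower number from compound 3 to compound 4 (2.40 log units; beyond the scatter) in this assay and ethyl in place of hydroxy brings a 1000-fold lower number from compound 2 to compound 4 (3.00 log units; beyond the scatter) at the same place, so this nitrogen is far more sensitive than the earlier modest step suggested. Ethyl alone does not give the low number, since compound 1 also carries it. Methyl in place of cyano on an aromatic carbon brings a 250-fold lower number from compound 1 to compound 4 (2.40 log units; beyond the scatter) as well. No measured evidence explains these steps. On these data alone, whether a methyl, a longer chain or an amine on this nitrogen, or a methoxy group on the aromatic carbon, would keep so low a number stays open.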